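The compounds below may be only part of what the source reports. "The series", "measured", "known", "first", "only" and "open" are said of these compounds alone.

Measured so far in an ADME assay on HEK293 cells (Homo sapiens) for cytotoxicity, read by luminescence, with a stated time of 72 h; on this read-out higher numbers stand for an effect only at larger amounts of compound and lower numbers for an effect already at smaller amounts:

Compound 1 `CCOC(=O)c1c(-c2cccc(OC(C)C)c2)[nH]c2cc(OC)ccc2c1=O` gives > 22000 nM, which is a limit of the assay and not a number.
Compound 2 `CCOC(=O)c1c(-c2cccc(OC(F)(F)F)c2)[nH]c2cc(OC)ccc2c1=O` gives > 22000 nM, likewise a limit of the assay.
Compound 3 `CCOC(=O)c1c(-c2cccc(OC)c2)[nH]c2cc(OC(C)C)ccc2c1=O` gives > 22000 nM, likewise a limit of the assay.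

All three results sit at the limit of > 22000 nM in this assay, at which 3 of the 3 values shown sit, so no measured number exists for any of them. The change from compound 1 to compound 2 is trifluoromethyl in place of isopropyl on an oxygen on an aromatic ring. In this assay, on these data alone, it gives a step that the two limits leave unreadable from compound 1 to compound 2, so the size of that step stays unknown.

Compound 4 `CCOC(=O)c1c(-c2cccc(OC)c2)[nH]c2cc(OC(F)(F)F)ccc2c1=O` is not yet measured. It differs from compound 3 by trifluoromethyl in place of isopropyl on an oxygen on an aromatic ring, the same change as from compound 1 to compound 2, at the same place. How the core of compound 3 differs from the core of compound 1 is not broken down here.

The expectation for compound 4 rests on compound 3, whose result is the limit > 22000 nM. It also rests on the unreadable step that the two limits leave unreadable from compound 1 to compound 2, which gave no sign of any effect inside the measured range. The step from compound 3 to compound 4 is therefore expected to be a step that the limit leaves unreadable from compound 3 to compound 4. For compound 4 the estimate in this assay is 30000 nM, expected between 15000 nM and 100000 nM, most likely again reported only as a limit.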

Compound 4, half-maximal effective concentration: > 22000 nM
Compound 4 was reported as a limit; the forecaster's own chance of this, stated with the estimate: 85%; the middle value does not contradict the limit.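

Compound 3 and compound 4 both stand as limits of the assay and not as numbers, so no step can be read between them, and trifluoromethyl in place of isopropyl still has no readable size. The compounds shown leave open whether any of them would give a measured number in this assay, and whether that change shifts such a number at all: the limit of > 22000 nM in this assay, at which 4 of the 4 values shown sit.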